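This account rests on a few compounds, and the source may have more. Where it says the series, first, only, none or still open, it means among the compounds named here.

Three compounds have been measured so far in a functional assay on CCRF-CEM cells (Homo sapiens) for cytotoxicity; a lower number here means a stronger inhibitor, a higher number a weaker inhibitor:

compound 1 `C=C1C(=O)O[C@H]2C[C@@H](C)C3=C(C[C@H]12)[C@@]1(C)C[C@@H]3C[C@@]12C(=O)O[C@@H]1C[C@@]3(C)[C@@H](O)C[C@@H](O)C(=C)[C@@H]3C[C@@H]12` gives 140 nM
compound 2 `C=C1C(=O)O[C@H]2C[C@H](C)C3=C(C[C@H]12)[C@@]1(C)C[C@@H]3C[C@@]12C(=O)O[C@H]1C=C(C)[C@H]3CC[C@@](C)(O)[C@@H]3C[C@@H]12` gives 2030 nM
compound 3 `C=C1C(=O)O[C@H]2C[C@H](C)[C@@]34C[C@@H](C[C@@]35C(=O)O[C@H]3CC(=C)[C@H]6CC[C@@](C)(O)[C@@H]6C[C@@H]35)C(C)=C4C[C@H]12` gives 2030 nM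

Compound 1 has the lowest number of the three, which makes it the strongest inhibitor in this small set. Compound 2 and compound 3 share one value, and each lies beyond the usual scatter of repeat measurements from compound 1.

Compound 4 `C=C1C(=O)O[C@H]2C[C@H](C)C3=C(C[C@H]12)[C@@]1(C)C[C@@H]3C[C@@]12C(=O)O[C@@H]1C[C@@]3(C)[C@@H](O)C[C@@H](O)C(=C)[C@@H]3C[C@@H]12` has not yet been measured in this assay. Set against compound 1, it has the same atoms and bonds and differs only in configuration as drawn (the two compounds have the same atoms and bonds and differ only in configuration as drawn: 1 of 12 stereo elements differ; a stereocentre at a saturated ring carbon is drawn R in compound 1 and S in compound 4): a stereocentre at a saturated ring carbon is drawn R in compound 1 and S in compound 4.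

Within the data shown here, no two measured compounds differ in just one place, so the data give no direct measure of what such a change does. Still, compound 1 at 140 nM holds the lowest number in hand, so a rise seems more likely than a fall. The expected change is a modest rise, toward a weaker inhibitor, estimated as a 2.1-fold higher number from compound 1 to compound 4 (0.33 log units; beyond the scatter), and it may stay close to the scatter. For compound 4 the estimate is 300 nM, with an expected range from 90 nM to 1200 nM.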

Compound 4, half-maximal inhibitory concentration: 140 nM
The estimate for compound 4 lay 2.1-fold (0.33 log units) above the measured number, and the stated range covers the measured number.
By their numbers in this assay, from the lowest: compounds 1 and 4 (each within the scatter of the next); then compounds 2 and 3 (each within the scatter of the next).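

In this assay the result is no change at the digits printed from compound 1 to compound 4 (within the scatter), which gives the set its first direct reading of a single change. At this saturated ring carbon, the drawn R and S forms cannot be told apart by this read-out, so the cytotoxicity measured here does not depend on how this one stereocentre is drawn, at least within the shared core of this pair. The reading can be tied to that one stereocentre because nothing else separates the two structures: the fact that compounds 1 and 4 differ only in the configuration as drawn

Among these compounds, no other measured pair differs in just one place, so the features of the structure that do set the number in these cells remain unidentified. From the compounds shown here alone, it also remains open whether this ring carbon would accept a different group as readily as it accepts the change in configuration, for example an amine, a hydroxyl group or a longer chain such as propyl, and whether the same match between the two forms would hold in other cell lines.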